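Chain Length and Trifluoromethyl Position in a Seizure Model

The source may report more compounds than this note shows. Statements on the series, on what has been measured and on what is new or still open speak of the compounds shown alone.

Of the compounds shown here, three have been tested in a functional assay on the whole organism (strain Swiss) with Mus musculus as the target, in the maximal electroshock model, with a stated time of 1 h, at a dose of 300 mg/kg by the intraperitoneal route; a lower number here means a weaker effect, a higher number a stronger effect of the compound at the dose given. Compound 1 `CC(C(=O)N1CCN(c2ccccc2C(F)(F)F)CC1)N1C(=O)CCC1=O` gives 75% in this assay, compound 2 `CCC(C(=O)N1CCN(c2ccccc2C(F)(F)F)CC1)N1C(=O)CCC1=O` gives 0%, and compound 3 `CCC(C(=O)N1CCN(c2cccc(C(F)(F)F)c2)CC1)N1C(=O)CCC1=O` gives 100%, the highest of the three, with every step to the others beyond the scatter. Compounds 2 and 3 hold the same atoms joined differently; the difference between their two cores is not broken down here. Between compound 2 and compound 1 the change is hydrogen in place of methyl on a saturated chain carbon, two bonds along the chain from an amide-type nitrogen in a ring and a carbonyl carbon, and it produced a number 75 percentage points higher from compound 2 to compound 1 (beyond the scatter).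

Compound 4 `CC(C(=O)N1CCN(c2cccc(C(F)(F)F)c2)CC1)N1C(=O)CCC1=O` has not yet been measured in this assay. It differs from compound 3 by hydrogen in place of methyl on a saturated chain carbon, two bonds along the chain from an amide-type nitrogen in a ring and a carbonyl carbon, the same change at the same place, now made on the core of compound 3. The read-out can hardly rise further because compound 3 already gives 100%, and the earlier step of a number 75 percentage points higher from compound 2 to compound 1 (beyond the scatter) pointed upward, so the expected step is no change at the digits printed from compound 3 to compound 4 (within the scatter). Compound 4 is therefore estimated at 100%, with a range from 75% to 100%.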

Compound 4, a percentage reported as activity, at one dose (the size of the read-out at that dose, not a potency): 100%
Compound 4: middle estimate and measured number agree at the digits printed; low and high end bracket the measured number.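

On the second core, the change of ethyl to methyl gave no change at the digits printed from compound 3 to compound 4 (within the scatter) in this assay. This flat step says little about the size of the change on this core: compound 3 gives 100% and compound 4 gives 100%, so the read-out has no room left to rise, and a single dose cannot separate the two compounds any further. What the two steps do show is that the change did not carry over from one core to the other with the same size, although two pairs do not explain that gap or set a rule for the series: the same change on two cores in this assay, a number 75 percentage points higher (beyond the scatter) from compound 2 to compound 1 and no change at the digits printed (within the scatter) from compound 3 to compound 4, 75 percentage points apart, beyond the scatter of two such steps

From the compounds shown here alone, whether a longer chain such as propyl, or a phenyl group, on this chain carbon would keep the read-out of compound 3 or lose it as compound 2 does remains open. So does the outcome of replacing trifluoromethyl with chlorine or methoxy on either core, and how compound 3 and compound 4 would compare at a lower dose.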